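Spiro series, liver cell antiproliferation: outlook for compound 4

The source may report more compounds than this note shows. Statements on the series, on what has been measured and on what is new or still open speak of the compounds shown alone.

Compound 1, `Cc1ccccc1-n1nncc1CN1C(=O)C2(C(C#N)=C(N)Oc3c2c2nc4ccccc4nc2c2ccccc32)c2ccccc21`: > 50000 nM (a limit)
Compound 2, `N#CC1=C(N)Oc2c(c3nc4ccccc4nc3c3ccccc23)C12C(=O)N(Cc1cnnn1-c1ccc(F)c(Cl)c1)c1ccccc12`: > 50000 nM (a limit)
Compound 3, `N#CC1=C(N)Oc2c(N)cc3nc4ccccc4nc3c2C12C(=O)N(Cc1cnnn1-c1ccc(F)cc1)c1ccccc12`: > 50000 nM (a limit)

In an ADME assay on L02 cells (Homo sapiens) for antiproliferative activity, read by MTT assay, with a stated time of 48 h (on this read-out higher numbers stand for weaker inhibition and lower numbers for stronger inhibition), compound 1 sits at a limit, > 50000 nM. Compound 2 likewise sits at a limit, > 50000 nM. Compound 3 also sits at a limit, > 50000 nM. Each of these values is a limit of the assay, not a number. Going by the values given here, the single step between measured compounds, a step that the two limits leave unreadable from compound 1 to compound 2, is for that reason unreadable. Compound 3 thus stands at the limit together with the two other measured compounds, as the limit of > 50000 nM in this assay, at which 3 of the 3 values shown sit, shows, and nothing ranks it against them.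

Compound 4, `Cc1ccc(-n2nncc2CN2C(=O)C3(C(C#N)=C(N)Oc4c(N)cc5nc6ccccc6nc5c43)c3ccccc32)cc1Cl`, differs from compound 3 in one place: 3-chloro-4-methylphenyl in place of 4-fluorophenyl on an aromatic nitrogen. Among the compounds with values here, the only measured step, a step that the two limits leave unreadable from compound 1 to compound 2, also exchanges one aryl group on the same aromatic nitrogen, but its size is not readable, so neither a direction nor a size can be drawn from it. With all three values sitting at the limit per (the limit of > 50000 nM in this assay, at which 3 of the 3 values shown sit), the expectation for compound 4 is that it too falls at or beyond the limit. The expected step, a step that the limit leaves unreadable from compound 3 to compound 4, is none beyond the scatter. Compound 4 is accordingly estimated at 70000 nM, with a range from 20000 nM to 250000 nM.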

Compound 4, half-maximal inhibitory concentration: > 50000 nM
Compound 4 gave a limit, no number; the forecaster's own chance of this, stated with the estimate: 80%; the middle value is on the limit's open side.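

In this assay compound 4 gives > 50000 nM, a limit and not a number. No step can be read from compound 3 to compound 4, as the whole series shown stands at one limit: the limit of > 50000 nM in this assay, at which 4 of the 4 values shown sit. The compounds shown leave open whether any aryl group on the aromatic nitrogen would give a measurable value in this assay.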